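Two anilines measured, an ethoxy analogue awaits

This account rests on a few compounds, and the source may have more. Where it says the series, first, only, none or still open, it means among the compounds named here.

Compound 1 `COc1cccc(NC2=CC(=O)c3c(nc4n3[C@H]3OC[C@@H](O)[C@H]3OC4)C2=O)c1` and compound 2 `COc1ccc(NC2=CC(=O)c3c(nc4n3[C@H]3OC[C@@H](O)[C@H]3OC4)C2=O)cc1` were tested in a functional assay on MGC-803 cells (Homo sapiens) for inhibition, read by sulforhodamine B assay; a higher number here means a weaker inhibitor, a lower number a stronger inhibitor; compound 1 gives 1790 nM and compound 2 gives 2150 nM. Compound 1 holds the lower of the two numbers, although the step of a 1.2-fold higher number from compound 1 to compound 2 (0.08 log units; within the scatter) lies within the scatter. Compound 3 `CCOc1ccc(NC2=CC(=O)c3c(nc4n3[C@H]3OC[C@@H](O)[C@H]3OC4)C2=O)cc1` differs from compound 1 by 4-ethoxyphenyl in place of 3-methoxyphenyl on an amine nitrogen. Among the measured compounds shown here, only that one measured step bears on this change, and no measured pair compares a 4-methoxyphenyl with a 4-ethoxyphenyl. Compound 3 is therefore expected to show no step beyond the scatter, a 1.2-fold higher number from compound 1 to compound 3 (0.09 log units; within the scatter). Compound 3 is estimated at 2200 nM in this assay, within 1000 nM to 4800 nM.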

Compound 3, half-maximal inhibitory concentration: 2090 nM
Estimate against measurement, compound 3: 1.1-fold (0.02 log units) above; measured number inside the range.
By their numbers in this assay, from the lowest: compounds 1, 3 and 2 (each within the scatter of the next).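

In this assay, among the compounds shown here, the 4-ethoxyphenyl on the amine nitrogen gives a 1.2-fold higher number from compound 1 to compound 3 (0.07 log units; within the scatter), and the added methyl on the saturated chain carbon bound to the oxygen gives a 1.0-fold lower number from compound 2 to compound 3 (0.01 log units; within the scatter), the first measured pair to compare a 4-methoxyphenyl with a 4-ethoxyphenyl. Across compounds 1, 2 and 3, neither the methyl nor the change of aryl group produces a step beyond the scatter. No evidence is available to explain these results. The compounds shown leave open whether a carboxylic acid or an amine in place of the ethoxy group would produce a step beyond the scatter. From the compounds shown here alone, a longer chain on that oxygen remains equally open.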